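This account rests on a few compounds, and the source may have more. Where it says the series, first, only, none or still open, it means among the compounds named here.

In an ADME assay on MT4 cells (Homo sapiens) for cytotoxicity, read by MTT assay, with a stated time of 96 h (a lower number here means that less compound is tolerated, a higher number that more compound is tolerated), compound 1, `CC(=O)c1ccc2c(c1)nc(-c1ccoc1)n2C1CCCCC1`, gives 63000 nM. Compound 2, `CC(=O)c1ccc2[nH]c(-c3ccoc3)nc2c1`, differs from it by hydrogen in place of cyclohexyl on an aromatic nitrogen. In this assay compound 2 reaches only a limit of the assay, > 100000 nM. That step, an at least 1.5-fold higher number from compound 1 to compound 2 (0.20 log units; that floor lies within the scatter), is therefore known only as a floor, because of the limit of > 100000 nM in this assay, at which 1 of the 3 values shown sits. Compound 3, `C/C(=N\NC(N)=S)c1ccc2c(c1)nc(-c1ccoc1)n2C1CCCCC1`, differs from compound 1 by a group of 7 heavy atoms (3 carbon, 3 nitrogen, 1 sulfur; no ring) in place of a group of 3 heavy atoms (2 carbon, 1 oxygen; no ring), on an aromatic carbon, and in this assay compound 3 gives 21000 nM, a step of a 3.0-fold lower number from compound 1 to compound 3 (0.48 log units; beyond the scatter).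

Compound 4, `C/C(=N\NC(N)=S)c1ccc2[nH]c(-c3ccoc3)nc2c1`, has not yet been measured in this assay. It differs from compound 3 by hydrogen in place of cyclohexyl on an aromatic nitrogen. The place described around this change is word for word the place described for the change from compound 1 to compound 2, so the two are the same change on two cores whose difference is given by a group of 7 heavy atoms (3 carbon, 3 nitrogen, 1 sulfur; no ring) in place of a group of 3 heavy atoms (2 carbon, 1 oxygen; no ring), on an aromatic carbon. The expectation for compound 4 rests on that earlier step, an at least 1.5-fold higher number from compound 1 to compound 2 (0.20 log units; that floor lies within the scatter), and on compound 3 standing at 21000 nM. Compound 4 is expected to show a 2.6-fold higher number from compound 3 to compound 4 (0.42 log units; beyond the scatter). The estimate for compound 4 in this assay is 55000 nM, within 22000 nM to 130000 nM.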

Compound 4, half-maximal cytotoxic concentration: 86000 nM
For compound 4 the middle estimate is 1.6-fold (0.19 log units) below the measured one, and the stated range covers the measured number.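

In this assay, hydrogen in place of cyclohexyl on the aromatic nitrogen gives a 4.1-fold higher number from compound 3 to compound 4 (0.61 log units; beyond the scatter), and on the two cores this change raises the number in the same direction, although its size is fixed on only one of them: the same change on two cores in this assay, an at least 1.5-fold higher number (0.20 log units; that floor lies within the scatter) from compound 1 to compound 2 and a 4.1-fold higher number (0.61 log units; beyond the scatter) from compound 3 to compound 4; the limit leaves it open whether they differ. Compound 2 stands at a limit of the assay, > 100000 nM, so the step to it is known only as a floor: the limit of > 100000 nM in this assay, at which 1 of the 4 values shown sits. The series therefore shows that the direction of the change carries from the core of compound 1 to the core of compound 3, but not that its size carries, and the step on the other side of the square, an at least 1.1-fold lower number from compound 2 to compound 4 (0.06 log units; that floor lies within the scatter), settles nothing further: the same change on two cores in this assay, a 3.0-fold lower number (0.48 log units; beyond the scatter) from compound 1 to compound 3 and an at least 1.1-fold lower number (0.06 log units; that floor lies within the scatter) from compound 2 to compound 4; the limit leaves it open whether they differ.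

The compounds shown hold only hydrogen and cyclohexyl on that nitrogen, so it stays open where a methyl group or a short alkyl chain would fall in this assay. As far as these compounds go, it also stays open whether an amine or a carboxylic acid on that nitrogen would follow the same direction on both cores.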